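Compound 3 to compound 4: a change of amide group

The source may hold more compounds than are shown below. What is called first, only, known or untested is meant among the compounds shown, and "the series" means these compounds.

In a functional assay on DU-145 cells (Homo sapiens) for antiproliferative activity, read by sulforhodamine B assay, with a stated time of 3 days (on this read-out higher numbers stand for weaker inhibition of growth and lower numbers for stronger inhibition of growth), compound 1 `COc1ccc(NC(=O)c2cccc(Nc3ncc(F)c(Nc4ccc(F)cc4)n3)c2)cc1` returns only a limit, > 10000 nM. Compound 2 `O=C(c1cccc(Nc2ncc(F)c(Nc3ccc(F)cc3)n2)c1)N1CCCCC1` gives 13000 nM. Compound 3 `O=C(Nc1cccc(Nc2ncc(F)c(Nc3ccc(F)cc3)n2)c1)c1ccncc1` gives 4330 nM, the lower of the two numbers available in this assay.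

Compound 4 `Cn1ccnc1NC(=O)c1cccc(Nc2ncc(F)c(Nc3ccc(F)cc3)n2)c1` differs from compound 3 in one place: (1-methyl-1H-imidazol-2-yl)carbamoyl in place of ((pyridin-4-yl)carbonyl)amino on an aromatic carbon. Here (1-methyl-1H-imidazol-2-yl)carbamoyl stands in place of ((pyridin-4-yl)carbonyl)amino on an aromatic carbon of a six-membered aromatic ring of carbon only.

Within the data shown here, two measured steps bear on this change. The first is a 3.0-fold lower number from compound 2 to compound 3 (0.48 log units; beyond the scatter), with ((pyridin-4-yl)carbonyl)amino entering in place of (piperidin-1-yl)carbonyl. The second is an at least 2.3-fold lower number from compound 1 to compound 3 (0.36 log units; beyond the scatter), with the same group entering in place of (4-methoxyphenyl)carbamoyl. Compound 4 gives that group up and carries a carbamoyl, as compound 1 does, so a modest rise in the number is expected, with compound 2 at 13000 nM as the nearest guide. The expected step is a 1.6-fold higher number from compound 3 to compound 4 (0.21 log units; within the scatter). For compound 4 the estimated value is 7000 nM, with an expected range from 2500 nM to 18000 nM.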

Compound 4, concentration for 50% growth inhibition: 15100 nM
Compound 4: the middle estimate sits 2.2-fold (0.33 log units) below what was measured; measured number inside the range.
By their numbers in this assay, from the lowest: compound 3; then compounds 2 and 4 (each within the scatter of the next).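

In this assay, the step of a 3.5-fold higher number from compound 3 to compound 4 (0.54 log units; beyond the scatter) shows that on this aromatic carbon, meta to a large group, (1-methyl-1H-imidazol-2-yl)carbamoyl does not match ((pyridin-4-yl)carbonyl)amino, although the two groups have the same number of heavy atoms and both hold an aromatic ring. The step of a 1.2-fold higher number from compound 2 to compound 4 (0.07 log units; within the scatter) stays within the scatter, so on the carbonyl carbon the (1-methyl-1H-imidazol-2-yl)amino group and the piperidin-1-yl group cannot be told apart, and among the compounds shown only compound 3, the one whose amide reaches the aromatic carbon through its nitrogen, stands clear of the others. The step involving compound 1 cannot be read, because compound 1 carries only a limit: the limit of > 10000 nM in this assay, at which 1 of the 4 values shown sits.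

The compounds shown leave open whether the lower number of compound 3 goes with the direction of its amide or with its pyridine ring, as the two change together in every step. They also leave open how a benzoylamino group, a (pyridin-4-yl)carbamoyl group, or a carboxylic acid on the same aromatic carbon would read.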